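Lengthening a Phosphate Chain Before the Result Is Known

A few compounds are considered here, and "the series" means these few. Any claim that something is new, unique, unknown or untested is made for them only; others in the source may bear on it.

Compound 1 `O=c1ccn(COCCOP(=O)(O)O)c(=O)[nH]1` was tested in a functional assay on NG108-15 cells for antagonist activity at P2Y purinoceptor 2 (Mus musculus), read by fluorescence and calcium flux, with a stated time of 30 min; a lower number here means a stronger inhibitor, a higher number a weaker inhibitor. In this assay compound 1 gives > 500000 nM, which is a limit of the assay rather than a number. Compound 2 `O=c1ccn(COCCCOP(=O)(O)O)c(=O)[nH]1` gives 338000 nM in this assay. Within the data shown here, the only measured step, an at least 1.4-fold lower number from compound 1 to compound 2 (0.17 log units; that floor lies within the scatter), lies within the scatter, and compound 1 sits at the limit of > 500000 nM in this assay, at which 1 of the 2 values shown sits. Compound 3 `O=c1ccn(COCCOP(=O)(O)OP(=O)(O)OP(=O)(O)O)c(=O)[nH]1` differs from compound 1 by a group of 8 heavy atoms (6 oxygen, 2 phosphorus; no ring) in place of a hydrogen atom, on an oxygen. No measured step alters that place, so nothing shown predicts this change in this assay. Compound 3 is therefore expected to give roughly 200000 nM, somewhere between 40000 nM and 500000 nM. That expectation amounts to an at least 2.5-fold lower number from compound 1 to compound 3 (0.39 log units; beyond the scatter).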

Compound 3, half-maximal inhibitory concentration: 500000 nM
The estimate for compound 3 lay 2.5-fold (0.40 log units) below the measured number, within the range that was stated.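

Among these compounds, putting a group of 8 heavy atoms (6 oxygen, 2 phosphorus) on an oxygen whose other neighbours are phosphorus gives the first actual number at this place: in this assay compound 3 gives 500000 nM. Compound 1 has only a limit of the assay: the limit of > 500000 nM in this assay, at which 1 of the 3 values shown sits. The step is a number no higher from compound 1 to compound 3 (the limit leaves the size open) and so this change is shown neither to strengthen nor to weaken inhibition. Open still is what a carboxylic acid or an amine on that oxygen would give, and what this group would give on the longer chain of compound 2.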